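Swapping a halogenated phenyl for an ethoxyphenyl

A few compounds are considered here, and "the series" means these few. Any claim that something is new, unique, unknown or untested is made for them only; others in the source may bear on it.

Going by the values given here, compound 1 `CC[C@@H](Nc1c(C#N)c(-c2ccc(-c3cccc(Cl)c3F)cc2)nc2cnccc12)C(N)=O` is one of only two compounds measured in a physicochemical assay for lipophilicity, read by HPLC, at pH 7.5 (a higher number here means a more lipophilic compound, a lower number a more polar compound), and compound 1 gives 3.1 there. The other measured compound, compound 2 `CC(C)(CC(N)=O)c1c(C#N)c(-c2ccc(Br)cc2)nc2cnccc12`, gives 2.1 in this assay. Compound 1 therefore stands at the higher of the two numbers, and the gap to compound 2 lies beyond the usual scatter, so compound 1 is the more lipophilic of the pair as measured.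

Compound 3 `CCOc1ccccc1-c1ccc(-c2nc3cnccc3c(N[C@H](CC)C(N)=O)c2C#N)cc1` has not yet been measured in this assay. It differs from compound 1 in a single place: 2-ethoxyphenyl in place of 3-chloro-2-fluorophenyl on an aromatic carbon. Among the compounds with values here, no pair of measured compounds differs by just this change, so nothing in the two measured values directly anticipates its effect; the pair shows only that the distribution coefficient can move by a clear margin between members.

Compound 3 is expected to give 2.7, within a range from 2.3 to 3.1, because compound 1 starts from 3.1 and the exchange is expected to lower it modestly. The expected step in this assay a number 0.40 log units lower from compound 1 to compound 3 (beyond the scatter) is small, downward, and near the edge of the scatter.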

Compound 3, distribution coefficient: 3
Compound 3: middle estimate off by 0.30 log units, on the low side, and the stated range covers the measured number.
By their numbers in this assay, from the lowest: compound 2; then compounds 3 and 1 (each within the scatter of the next).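

Going by these compounds alone, on the aromatic carbon para to a large group, the exchange of 3-chloro-2-fluorophenyl for 2-ethoxyphenyl gives the first single-place step in this assay (a number 0.10 log units lower from compound 1 to compound 3 (within the scatter)), so this measurement does not separate the two compounds. The exchange is a substantial one in make-up: both halogens leave, an oxygen-bearing ethoxy chain enters, the substituent goes from 8 to 9 heavy atoms, and its hydrogen-bond acceptors go from 0 to 1, yet the read-out stays within the scatter for this pair. Nothing shown here gives a measured reason for that closeness.

As far as these compounds go, what remains open is whether this carbon would tolerate quite different substituents with the same result, such as an amine, a carboxylic acid or a longer alkoxy chain on the phenyl ring, and whether the ethoxy group would behave alike on the other carbons of that ring. Compound 2 differs from compound 1 and compound 3 in more than one place, so it offers no comparison for this exchange, and a single pair cannot show whether the outcome holds beyond compound 1 and compound 3.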